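This account rests on a few compounds, and the source may have more. Where it says the series, first, only, none or still open, it means among the compounds named here.

Compounds measured so far:
compound 1 `CCCCCCCC/C=C\CCCCCCCCNC(=O)Nc1ccc(F)cc1F` gives 4700 nM
compound 2 `CCCCCCCCCCCCCCCCCCNC(=O)Nc1c(C)cccc1Cl` gives 1100 nM
compound 3 `CCCCCCCCCCCCCCNC(=O)Nc1ccc(F)cc1F` gives 340 nM

In an assay on microsomes from intestinal mucosa for inhibition of acyl-CoA:cholesterol acyltransferase (Oryctolagus cuniculus) (on this read-out higher numbers stand for weaker inhibition and lower numbers for stronger inhibition), compound 3 gives 340 nM, the lowest of the three numbers; compound 2 stands nearest to it, and compound 1 furthest. Compound 4 `CCCCCCCCCCCCCCNC(=O)Nc1c(C)cccc1Cl` has not yet been measured. It differs from compound 3 in one place: 2-chloro-6-methylphenyl in place of 2,4-difluorophenyl on an amide-type nitrogen.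

For the measured compounds named here, no measured step isolates this change. Going by the values given here, the only step measured, a 14-fold lower number from compound 1 to compound 3 (1.14 log units; beyond the scatter), concerns the chain and not the ring, so it says nothing direct about the ring swap. Compound 2 carries the same 2-chloro-6-methylphenyl as compound 4 but a longer chain, so compound 2 and compound 3 differ in two places and their values cannot be pulled apart. Compound 1 and compound 2 both carry long chains, and compound 2 gives the lower number of the two, which hints that the ring swap is not expected to cost much. Compound 4 is therefore expected to land near compound 3, with a 1.4-fold lower number from compound 3 to compound 4 (0.13 log units; within the scatter) small, and its value estimated at 250 nM, between 80 nM and 800 nM.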

Compound 4, half-maximal inhibitory concentration: 70 nM
Compound 4: middle estimate off by 3.6-fold (0.55 log units), on the high side; the whole stated range lies above it.
By their numbers in this assay, from the lowest: compound 4; then compound 3; then compound 2; then compound 1.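

For the compounds shown here, with the chain held the same, 2-chloro-6-methylphenyl in place of 2,4-difluorophenyl on an amide-type nitrogen gives in this assay a 4.9-fold lower number from compound 3 to compound 4 (0.69 log units; beyond the scatter) and beyond the scatter, which shows that the ring on this nitrogen alters the number by itself, something the earlier compounds could not separate from the chain. With 2-chloro-6-methylphenyl held in place, hydrogen in place of butyl on a saturated chain carbon gives a 16-fold lower number from compound 2 to compound 4 (1.20 log units; beyond the scatter) and so shows that the chain also matters with this ring, by a step larger than the ring swap. Nothing available explains why either change lowers the number.

The compounds shown leave open whether a shorter chain would lower the number further. They also leave open how an amine or a carboxylic acid on the ring would compare with the methyl and chlorine of compound 4.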